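The compounds below may be only part of what the source reports. "The series", "measured", "known", "first", "only" and "open" are said of these compounds alone.

Among the measured compounds shown here, in a functional assay on A549 cells (Homo sapiens) for cytotoxicity, read by MTT assay, with a stated time of 72 h (on this read-out higher numbers stand for weaker inhibition and lower numbers for stronger inhibition), compound 1 `O=C(CN1CCN(c2nnc(Cc3ccccc3)c3ccccc23)CC1)Nc1ccc(F)c(F)c1` gives 10100 nM and compound 2 `O=C(CN1CCN(c2nnc(Cc3ccccc3)c3ccccc23)CC1)Nc1ccc(Br)cc1` gives 2000 nM; the only measured step, a 5.1-fold lower number from compound 1 to compound 2 (0.70 log units; beyond the scatter), shows that a change on this aromatic ring can move the number. Compound 3 `O=C(CN1CCN(c2nnc(Cc3ccccc3)c3ccccc23)CC1)Nc1cccc(Br)c1` stands apart: in this assay compound 3 was reported as "not active" (no number reported), so no single number places it against the other two. Compound 4 `O=C(CN1CCN(c2nnc(Cc3ccccc3)c3ccccc23)CC1)Nc1cccc(F)c1` differs from compound 3 in one place: fluoro in place of bromo on an aromatic carbon. For the measured compounds named here, no measured step covers this swap, and compound 3 offers no number to start from, so any expectation rests only on compound 3 being inactive and on the weak number of compound 1. For compound 4 a weak result is expected, estimated at 20000 nM with a range from 5000 nM to 80000 nM, and an inactive report remains quite possible.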

Compound 4, half-maximal inhibitory concentration: 130000 nM
The estimate for compound 4 lay 6.5-fold (0.81 log units) below the measured number; measured number above the stated range.
By their numbers in this assay, from the lowest: compound 2; then compound 1; then compound 4.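

In this assay, compound 4 shows that a ring with a single 3-fluorophenyl pattern can still give a number, though a very weak one, while the swap from compound 3 cannot be read as a step. Hydrogen in place of fluoro on the ring of compound 1 costs much (a 13-fold higher number from compound 1 to compound 4 (1.11 log units; beyond the scatter)), and 3-fluorophenyl falls far behind 4-bromophenyl (a 65-fold higher number from compound 2 to compound 4 (1.81 log units; beyond the scatter)). No measurement here explains why these numbers shift. As far as these compounds go, it remains open whether 4-fluorophenyl, or a ring carrying an amine or a carboxylic acid, would come closer to compound 2.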